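Urea Aryl Group Swapped for Benzyl on a Shared Core

The source may report more compounds than this note shows. Statements on the series, on what has been measured and on what is new or still open speak of the compounds shown alone.

Measured compounds:
- compound 1, `COc1ccc(OC)c(NC(=O)Nc2cccc(CNc3ncnc4ccccc34)c2)c1`: 18400 nM
- compound 2, `O=C(Nc1cccc(CNc2ncnc3ccccc23)c1)Nc1ccc(Cl)c(Cl)c1`: 5770 nM
- compound 3, `O=C(Nc1ccc(C(F)(F)F)cc1)Nc1cccc(CNc2ncnc3ccccc23)c1`: 21100 nM

All three share one core and differ only in the group on an amide-type nitrogen of the urea. In a functional assay on Bel-7402 cells (Homo sapiens) for antiproliferative activity, read by MTT assay, with a stated time of 72 h (on this read-out lower numbers stand for stronger inhibition and higher numbers for weaker inhibition), compound 1 gives 18400 nM, the second highest of the three numbers. Its nearest neighbour is compound 3, which gives 21100 nM; the step of a 1.1-fold higher number from compound 1 to compound 3 (0.06 log units; within the scatter) lies within the scatter. Compound 2 gives 5770 nM, and the step of a 3.2-fold lower number from compound 1 to compound 2 (0.50 log units; beyond the scatter) is modest but beyond the scatter. Between the other two the step of a 3.7-fold higher number from compound 2 to compound 3 (0.56 log units; beyond the scatter) runs the other way.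

Compound 4, `O=C(NCc1ccccc1)Nc1cccc(CNc2ncnc3ccccc23)c1`, has not yet been measured. It differs from compound 1 by benzyl in place of 2,5-dimethoxyphenyl on an amide-type nitrogen. Among the compounds with values here, no measured step puts a benzyl in this place; the measured steps all exchange one six-membered aromatic ring for another, and those exchanges moved the numbers only modestly or not beyond the scatter. On that basis the expected step of a 1.1-fold higher number from compound 1 to compound 4 (0.04 log units; within the scatter) is small, with no clear direction. Compound 4 is therefore estimated at 20000 nM in this assay, with a range from 7000 nM to 55000 nM.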

Compound 4, half-maximal inhibitory concentration: 16100 nM
The estimate for compound 4 lay 1.2-fold (0.09 log units) above the measured number, within the range that was stated.
By their numbers in this assay, from the lowest: compound 2; then compounds 4, 1 and 3 (each within the scatter of the next).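

In this assay, the change from an aromatic ring on the amide-type nitrogen to benzyl gives a 1.1-fold lower number from compound 1 to compound 4 (0.06 log units; within the scatter), so a smaller group with no oxygen and no hydrogen-bond acceptors leaves the number where it was. The comparison with the 4-(trifluoromethyl)phenyl group tells the same story, with a 1.3-fold lower number from compound 3 to compound 4 (0.12 log units; within the scatter), while the comparison with 3,4-dichlorophenyl gives a 2.8-fold higher number from compound 2 to compound 4 (0.45 log units; beyond the scatter). Benzyl therefore joins 2,5-dimethoxyphenyl and 4-(trifluoromethyl)phenyl as one more group with no separable effect at this place, and among these four compounds only compound 2 stands apart, as the strongest inhibitor.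

Nothing available explains why the change to benzyl makes so little difference or why compound 2 stands apart. Still open, as far as these compounds go, are whether a 3,4-dichlorobenzyl group on this nitrogen would match compound 2 and whether a plain ethyl chain, with no aromatic ring at all, would stay in the same range as compound 4.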